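Purine-based hydroxamate-free amide series, antiproliferative read-out

A few compounds are considered here, and "the series" means these few. Any claim that something is new, unique, unknown or untested is made for them only; others in the source may bear on it.

Measured compounds:
compound 1 `CN1CCN(c2nc(Cl)nc3c2ncn3Cc2ccc(C(=O)Nc3ccccc3N)cc2)CC1`: 55.1%
compound 2 `CC(C)n1cnc2c(Nc3cccc(Cl)c3)nc(NCOCc3ccc(C(=O)Nc4ccccc4N)cc3)nc21`: 43.2%
compound 3 `CCCCn1cnc2c(Nc3ccccc3)nc(NCOCc3ccc(/C=C/C(=O)Nc4ccccc4N)cc3)nc21`: 34.2%

In a functional assay on NCI-H460 cells (Homo sapiens) for antiproliferative activity, read by CCK-8 assay, with a stated time of 72 h, tested at 8 uM (on this read-out higher numbers stand for a stronger effect at the one concentration tested and lower numbers for a weaker effect), compound 1 gives 55.1%, the highest of the three numbers. Compound 2 stands nearest to it, with a number lower by a gap beyond the scatter, and compound 3 stands furthest, also beyond the scatter. For the measured compounds named here, compounds 2 and 3 are not single-point neighbours of compound 1, so no step between measured compounds is available here; their two values only show that the other two arrangements of the shared core gave lower inhibition.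

Compound 4 `Nc1ccccc1NC(=O)c1ccc(Cn2cnc3c(Nc4cccc(OC(F)(F)F)c4)nc(Cl)nc32)cc1` is not yet measured. It differs from compound 1 in one place: (3-(trifluoromethoxy)phenyl)amino in place of 4-methylpiperazin-1-yl on an aromatic carbon, on an aromatic carbon of the core, next to the ring nitrogen and meta to a chloro group. Going by the values given here, no measured pair shows this exchange. The expected step from compound 1 to compound 4 in this assay is a number 8.1 percentage points lower from compound 1 to compound 4 (within the scatter), downward and of a size near the edge of the scatter, since the two compounds that carry an arylamino group on the core, compound 2 and compound 3, both sit below compound 1. Compound 4 is therefore estimated at 47%, with a range from 28% to 65%.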

Compound 4, a percentage reported as inhibition, at one concentration (the size of the read-out at that concentration, not a potency): 62.4%
Compound 4: the middle estimate sits 15.4 percentage points below what was measured, within the range that was stated.
By their numbers in this assay, from the lowest: compounds 3 and 2 (each within the scatter of the next); then compounds 1 and 4 (each within the scatter of the next).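

For the compounds shown here, the step of a number 7.3 percentage points higher from compound 1 to compound 4 (within the scatter) in this assay is the first reading at this position of the core, on an aromatic carbon next to the ring nitrogen. It shows that 4-methylpiperazin-1-yl, a six-membered non-aromatic ring with 2 hetero atoms, and (3-(trifluoromethoxy)phenyl)amino, an aromatic ring of carbon only attached through an amino nitrogen, are not separated on this read-out. No evidence bears on why the two groups read alike.

Open, going by these compounds, is how much of this step belongs to the trifluoromethoxy group and how much to the arylamino attachment, a question for plain phenylamino at this position, and whether morpholin-4-yl or dimethylamino would fall with these two groups. On these data alone, the read-out gives a size at one concentration, so the potency of the pair also remains open.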